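Compound 3 without its benzyl group

This account rests on a few compounds, and the source may have more. Where it says the series, first, only, none or still open, it means among the compounds named here.

In a functional assay on KG-1 cells (Homo sapiens) for cytotoxicity, read by luminescence and CellTiter-Glo, with a stated time of 3 days (a higher number here means a weaker inhibitor, a lower number a stronger inhibitor), compound 3 (`N#Cc1ccc(NC(=O)c2cc(Cc3ccccc3)ccc2O)cc1`) gives 1930 nM and compound 2 (`N#Cc1ccc(NC(=O)c2ccc(Cl)cc2O)cc1`) gives 1920 nM within the scatter of each other. Compound 1 (`COc1ccc(O)c(C(=O)Nc2ccc(C#N)cc2)c1`) gives only > 10000 nM as a limit of the assay. Compound 4 (`N#Cc1ccc(NC(=O)c2ccccc2O)cc1`) differs from compound 3 by hydrogen in place of benzyl on an aromatic carbon with hydrogen in place of benzyl on an aromatic carbon. Among the compounds with values here, one measured step bears on this change: an at least 5.1-fold lower number from compound 1 to compound 3 (0.71 log units; beyond the scatter) with benzyl in place of methoxy. Its size rests on the limit of > 10000 nM in this assay, at which 1 of the 3 values shown sits, as a starting point. That step leads to the expectation of a modest move to a higher number in this assay once benzyl leaves, and the estimated step is a 2.6-fold higher number from compound 3 to compound 4 (0.41 log units; beyond the scatter) overall. The estimated value for compound 4 is 5000 nM (expected range 1800 nM to 15000 nM).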

Compound 4, half-maximal inhibitory concentration: 5370 nM
The estimate for compound 4 lay 1.1-fold (0.03 log units) below the measured number; the range from low to high includes it.
By their numbers in this assay, from the lowest: compounds 2 and 3 (each within the scatter of the next); then compound 4. At a limit, above all of these: compound 1.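

In this assay the unsubstituted position is now measured directly: hydrogen in place of benzyl gives a 2.8-fold higher number from compound 3 to compound 4 (0.44 log units; beyond the scatter) and this step does not rest on a limit. Hydrogen in place of chloro gives a 2.8-fold higher number from compound 2 to compound 4 (0.45 log units; beyond the scatter) and so both benzyl and chloro carry lower numbers than hydrogen in these compounds. Compound 1 stands only at a limit: the limit of > 10000 nM in this assay, at which 1 of the 4 values shown sits. Hydrogen in place of methoxy gives an at least 1.8-fold lower number from compound 1 to compound 4 (0.27 log units; that floor lies within the scatter) and this step rests on that limit.

The compounds shown leave open how an amine, a carboxylic acid or a longer chain in place of benzyl would compare with benzyl and hydrogen.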